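A few compounds are considered here, and "the series" means these few. Any claim that something is new, unique, unknown or untested is made for them only; others in the source may bear on it.

The three measured compounds share one core and differ only in the aryl group on the amide-type nitrogen. Compound 1 `O=C(CSc1nc(Nc2ccccc2)c2ccccc2n1)Nc1cccc(Br)c1` gives 10100 nM in a functional assay on NCI-H1975 cells (Homo sapiens) for inhibition, read by MTT assay, with a stated time of 72 h (a higher number here means a weaker inhibitor, a lower number a stronger inhibitor), compound 3 `O=C(CSc1nc(Nc2ccccc2)c2ccccc2n1)Nc1ccc(Cl)c(Cl)c1` gives 10400 nM, and compound 2 `C=CC(=O)Nc1cccc(NC(=O)CSc2nc(Nc3ccccc3)c3ccccc3n2)c1` gives 8120 nM. The number for compound 2 is the lowest of the three, but the steps of a 1.2-fold lower number from compound 1 to compound 2 (0.09 log units; within the scatter) and a 1.3-fold higher number from compound 2 to compound 3 (0.11 log units; within the scatter) both stay within the scatter, as does a 1.0-fold higher number from compound 1 to compound 3 (0.01 log units; within the scatter), so the three values are not told apart.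

Compound 4 `C=CC(=O)Nc1cccc(NC(=O)CSc2nc(Nc3ccc(CC)cc3)c3ccccc3n2)c1` keeps the whole of compound 2 and changes the other end of the molecule: ethyl in place of hydrogen on an aromatic carbon. Among the measured compounds shown here, none of the measured steps touches this anilino group; all three concern the aryl on the amide-type nitrogen, so there is no measured step that bears on the change from compound 2 to compound 4. With nothing to point in either direction, the expected step is a 1.0-fold lower number from compound 2 to compound 4 (0.01 log units; within the scatter), that is, no change beyond the scatter. Compound 4 is therefore estimated at 8000 nM in this assay, with a range from 3000 nM to 20000 nM.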

Compound 4, half-maximal inhibitory concentration: 8270 nM
Compound 4: middle estimate off by 1.0-fold (0.01 log units), on the low side, and the stated range covers the measured number.
By their numbers in this assay, from the lowest: compounds 2, 4, 1 and 3 (each within the scatter of the next).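

Among the compounds shown here, compound 4 gives the first reading at the anilino end of the molecule, which the earlier compounds left untouched. In this assay there is a 1.0-fold higher number from compound 2 to compound 4 (0.01 log units; within the scatter) and so, at this aromatic carbon para to a large group, ethyl in place of hydrogen leaves a number that cannot be told apart from that of compound 2. The data shown offer no measured basis for explaining this result.

The compounds shown leave open whether a longer chain, an amine or a carboxylic acid at this carbon would move the number beyond the scatter. They also leave open whether ethyl at this place would give the same result with the 3-bromophenyl group of compound 1 on the amide-type nitrogen.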